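Piperidinyl dioxolane series: hydroxy for chloro on the aryl ring

The compounds below may be only part of what the source reports. "The series", "measured", "known", "first", "only" and "open" are said of these compounds alone.

Of the compounds shown here, three have numbers so far in a functional assay (brain) for displacement of a labelled ligand, with Rattus norvegicus as the target; on this read-out higher numbers stand for weaker inhibition and lower numbers for stronger inhibition. Compound 1 `CCCCCCCCC[C@]1(c2ccccc2)OC[C@H]([C@@H]2CCCCN2)O1` gives 43000 nM. Compound 2 `CC[C@]1(c2ccc(Cl)cc2)OC[C@H]([C@@H]2CCCCN2)O1` gives 2800 nM, and compound 3 `CC[C@]1(c2cccc(O)c2)OC[C@H]([C@@H]2CCCCN2)O1` gives 489 nM. Among the three, compound 2 stands second highest: compound 3 sits at a lower number beyond the scatter, while compound 1 sits at a higher number, also beyond the scatter.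

The next compound, compound 4 `CC[C@]1(c2ccc(O)cc2)OC[C@H]([C@@H]2CCCCN2)O1`, differs from compound 2 in one place: hydroxy in place of chloro on an aromatic carbon. Going by the values given here, no measured pair shows this same change alone, so no step is known for it. What the numbers show is that compound 3, which carries a hydroxy group on its aromatic ring, gives a lower number in this assay than compound 2 with its chloro, but compound 3 is not a single-change partner of compound 4 and the comparison is only indicative.

The expectation for compound 4 is a move to a lower number, by a step of a 2.3-fold lower number from compound 2 to compound 4 (0.37 log units; beyond the scatter) that is expected to lie beyond the scatter but short of the value of compound 3. Compound 4 is estimated at 1200 nM in this assay, within a range of 350 nM to 4500 nM.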

Compound 4, inhibition constant: 19900 nM
For compound 4 the middle estimate is 17-fold (1.22 log units) below the measured one, and the stated range ends below it.
By their numbers in this assay, from the lowest: compound 3; then compound 2; then compound 4; then compound 1.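

In this assay, going by these compounds alone, the exchange of chloro for hydroxy on the aromatic carbon para to a large group gives a 7.1-fold higher number from compound 2 to compound 4 (0.85 log units; beyond the scatter) and so gives the first direct reading of this change, with chloro the group of the two that goes with the lower number at this position. A hydroxy on the aromatic ring therefore does not by itself go with a low number in this series: compound 3 with its hydroxy at another ring position stands at 489 nM in this read-out, so the position of the hydroxy may matter, though that single contrast cannot settle it. No measurement at hand accounts for the rise in the number on this change.

Open, going by these compounds, is whether the higher number is particular to hydroxy or would follow any replacement of chloro at this position, a question that methoxy, fluoro or an amine there would address. Also open, on these data alone, is whether chloro at the ring position held by the hydroxy of compound 3 would give a step of the same direction and size, and whether a longer chain in place of the ethyl group would alter this picture.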